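The source may report more compounds than this note shows. Statements on the series, on what has been measured and on what is new or still open speak of the compounds shown alone.

Three compounds have been measured in a functional assay on HepG2 cells (Homo sapiens) for cytotoxicity, read by MTT assay, with a stated time of 48 h (on this read-out higher numbers stand for weaker inhibition and lower numbers for stronger inhibition), so far:

- compound 1 `CC1=NN(C(=O)c2ccc([N+](=O)[O-])cc2)C(c2ccccc2O)C1` gives 30100 nM
- compound 2 `CC1=NN(C(=O)COc2ccc(Cl)cc2)C(c2cc(Br)cc(Br)c2O)C1` gives "not active" (no number reported) (no number reported)
- compound 3 `CCN(CC)CC(=O)N1N=C(C)CC1c1ccccc1O` gives 51600 nM

Compound 3 has one numerical neighbour, compound 1, and their two values lie within the usual scatter of each other. Compound 2 offers no number for comparison.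

The next compound is compound 4 `CC1=NN(C(=O)CN2CCN(C)CC2)C(c2ccccc2O)C1`, which has yet to be measured in this assay. Compared with compound 3, it carries 4-methylpiperazin-1-yl in place of diethylamino on a saturated chain carbon bound to a carbonyl carbon.

Among the measured compounds shown here, no two measured compounds differ in one place only, so the data give no direct guide to the size of this step. The expectation therefore rests on the value of compound 3, 51600 nM, and no shift beyond the scatter is anticipated. The expected change is a 1.1-fold lower number from compound 3 to compound 4 (0.06 log units; within the scatter). For compound 4 the estimated value is 45000 nM, with an expected range from 18000 nM to 110000 nM.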

Compound 4, half-maximal inhibitory concentration: "not active" (no number reported)
Compound 4 has no reported number here; no gap can be computed for the estimate.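

Among the compounds shown here, compound 4 has no reported number, so no step from compound 3 to compound 4 can be read. No measurement shown here bears on this result.

The compounds shown leave open how replacing diethylamino with 4-methylpiperazin-1-yl alters the cytotoxicity value, if at all.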